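Compound 4 against the limit of the series

The compounds below may be only part of what the source reports. "The series", "measured", "known", "first", "only" and "open" are said of these compounds alone.

Compound 3 `COc1cc(OC)c2c(c1)C(C(O)c1ccc(OCCOc3ccccc3)cc1)OC2=O` has no number to stand on: in a functional assay on RAW264.7 cells (Mus musculus) for inhibition, read by Griess assay, with stated times of 1 h and 24 h (a higher number here means a weaker inhibitor, a lower number a stronger inhibitor), compound 3 gives > 10000 nM, which is a limit. Compound 1 `COCCOc1ccc(C(O)C2OC(=O)c3c(OC)cc(OC)cc32)cc1` gives > 10000 nM, also a limit. Compound 2 `COCCCCOc1ccc(C(O)C2OC(=O)c3c(OC)cc(OC)cc32)cc1` reads 8210 nM. The measured steps are small or unreadable: an at least 1.2-fold lower number from compound 1 to compound 2 (0.08 log units; that floor lies within the scatter) and an at least 1.2-fold higher number from compound 2 to compound 3 (0.08 log units; that floor lies within the scatter) have floors within the scatter, and a step that the two limits leave unreadable from compound 1 to compound 3 has no readable size. In compound 4 `COc1cc(OC)c2c(c1)C(C(O)c1ccc(OCc3ccc(C)cc3)cc1)OC2=O`, 4-methylphenyl replaces phenoxymethyl on a saturated chain carbon bound to an oxygen on an aromatic ring (4-methylphenyl in place of phenoxymethyl on a saturated chain carbon bound to an oxygen on an aromatic ring). No step beyond the scatter is expected in this assay, and compound 4 is expected to stay weak because of the limit of > 10000 nM in this assay, at which 2 of the 3 values shown sit. The estimated step is an at least 1.1-fold lower number from compound 3 to compound 4 (0.04 log units; that floor lies within the scatter). For compound 4 the expected value is 9000 nM, with an estimated range of 3500 nM to 15000 nM.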

Compound 4, half-maximal inhibitory concentration: 3120 nM
Estimate against measurement, compound 4: 2.9-fold (0.46 log units) above, and the stated range ends above it.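

In this assay, 4-methylphenyl in place of phenoxymethyl, on a saturated chain carbon bound to an oxygen on an aromatic ring, gives a step at this position that clears the scatter: an at least 3.2-fold lower number from compound 3 to compound 4 (0.50 log units; beyond the scatter). The other two comparisons also clear it, with a 2.6-fold lower number from compound 2 to compound 4 (0.42 log units; beyond the scatter) and an at least 3.2-fold lower number from compound 1 to compound 4 (0.50 log units; beyond the scatter), so compound 4 is the strongest inhibitor of the four shown. Two compounds still sit at a limit: the limit of > 10000 nM in this assay, at which 2 of the 4 values shown sit.

Open, as far as these compounds go, is whether the step follows the methyl of 4-methylphenyl or the loss of the oxygen in phenoxymethyl. From the compounds shown here alone, an unsubstituted phenyl or a 4-chlorophenyl at this place would bear on that, and the effect of an amine here remains unknown.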